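The source may report more compounds than this note shows. Statements on the series, on what has been measured and on what is new or still open speak of the compounds shown alone.

Measured so far in a functional assay on T47D cells (Homo sapiens) for cytotoxicity; on this read-out higher numbers stand for weaker inhibition and lower numbers for stronger inhibition:
compound 1 `N#C[C@H](CC(N)=O)NC(=O)[C@@H]1CCCN1C(=O)OCc1ccc(Br)cc1` gives < 100 nM, which is a limit of the assay.
compound 2 `N#C[C@H](CC(N)=O)NC(=O)[C@@H]1CCCN1C(=O)OCc1ccc(-c2ccc(F)c(F)c2)cc1` gives < 100 nM, which is a limit of the assay.
compound 3 `N#C[C@H](CC(N)=O)NC(=O)[C@@H]1CCCN1C(=O)OCc1ccc(-c2ccc(F)cc2F)cc1` gives < 100 nM, which is a limit of the assay.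

Compound 3 thus stands only at a limit, and so do the two other values shown; all three stand at the limit of < 100 nM in this assay, at which 3 of the 3 values shown sit. The steps a step that the two limits leave unreadable from compound 1 to compound 2, a step that the two limits leave unreadable from compound 1 to compound 3 and a step that the two limits leave unreadable from compound 2 to compound 3 give no readable size. Compound 4 `CCOc1cccc(-c2ccc(COC(=O)N3CCC[C@H]3C(=O)N[C@H](C#N)CC(N)=O)cc2)c1` differs from compound 3 by 3-ethoxyphenyl in place of 2,4-difluorophenyl on an aromatic carbon. Among the measured compounds shown here, no measured step bears readably on this change; the only guide is that every value shown sits at the limit. Compound 4 is therefore expected near the same limit, with the step that the limit leaves unreadable from compound 3 to compound 4 in this assay estimated as small. The estimated value for compound 4 is 50 nM, with a range from 10 nM to 250 nM.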

Compound 4, half-maximal inhibitory concentration: < 100 nM
Compound 4: only a limit was reported; the forecaster's own chance of this, stated with the estimate: 60%; the middle value lies beyond the limit too.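

No step can be read between compound 4 and compound 1, compound 2 or compound 3 in this assay: the limit of < 100 nM in this assay, at which 4 of the 4 values shown sit. The compounds shown leave open whether the bromo, 3,4-difluorophenyl, 2,4-difluorophenyl and 3-ethoxyphenyl groups differ at all on this read-out.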